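The source may report more compounds than this note shows. Statements on the series, on what has been measured and on what is new or still open speak of the compounds shown alone.

Values in a functional assay on K562 cells (Homo sapiens) for antiproliferative activity, read by sulforhodamine B assay, with a stated time of 72 h (on this read-out higher numbers stand for weaker inhibition and lower numbers for stronger inhibition), for three compounds:
- compound 1 `O=C1CS/C(=N/Nc2nncc3ccccc23)N1c1ccccc1` gives 57 nM
- compound 2 `O=S(=O)(Nc1ncccn1)c1ccc(Nc2nncc3ccccc23)cc1` gives 43 nM
- compound 3 `O=C1CS/C(=N/Nc2nncc3ccccc23)N1` gives 85 nM

Compound 2, at 43 nM in this set, lies within the scatter of both compound 1 and compound 3, so none of the three stands apart. Compound 4 `Cc1cc(NS(=O)(=O)c2ccc(Nc3nncc4ccccc34)cc2)no1` carries 5-methyl-1,2-oxazol-3-yl in place of pyrimidin-2-yl on a sulfonamide nitrogen and is otherwise the same as compound 2. Going by the values given here, no measured step touches this place. The only one available, a 1.5-fold higher number from compound 1 to compound 3 (0.17 log units; within the scatter) (hydrogen in place of phenyl on an amide-type nitrogen in a ring), stays within the scatter and bears on the change only loosely. No shift beyond the scatter is therefore expected in this assay for this change. The expected step is a 1.2-fold higher number from compound 2 to compound 4 (0.07 log units; within the scatter) in size. For compound 4 the estimate is 50 nM (range 20 nM to 130 nM).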

Compound 4, half-maximal inhibitory concentration: 23 nM
Compound 4: the middle estimate sits 2.2-fold (0.34 log units) above what was measured; the range from low to high includes it.
By their numbers in this assay, from the lowest: compounds 4, 2, 1 and 3 (each within the scatter of the next, the first and the last beyond it).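

In this assay, going by these compounds alone, the sulfonamide nitrogen took 5-methyl-1,2-oxazol-3-yl in place of pyrimidin-2-yl with a 1.9-fold lower number from compound 2 to compound 4 (0.27 log units; within the scatter) as the only change, so at this place a five-membered aromatic ring can stand for a six-membered one without a shift beyond the scatter. Nothing at hand accounts for the size of this step.

As far as these compounds go, it remains open whether a plain phenyl, a longer alkyl chain or a bare hydrogen on that nitrogen would keep the number in this range. From the compounds shown here alone, whether the methyl of the 5-methyl-1,2-oxazol-3-yl matters also stays open.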